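Replacing a Piperidinyl Arm with a Triazolyl Ring

The compounds below may be only part of what the source reports. "The series", "measured", "known", "first", "only" and "open" are said of these compounds alone.

Compound 1 `O=C1O[C@@H](CN2CCCCC2)CN1c1ccc(-n2cc(-c3ccccn3)cn2)c(F)c1`: 3.1
Compound 2 `COC(=O)CC1CCN(C[C@H]2CN(c3ccc(-n4cc(-c5ccccn5)cn4)c(F)c3)C(=O)O2)CC1`: 1.78
Compound 3 `O=C1O[C@@H](Cn2ccnc2)CN1c1ccc(-n2cc(-c3ccccn3)cn2)c(F)c1`: 1.73

In a physicochemical assay for lipophilicity, read by HPLC, measured as octanol-water partition (a higher number here means a more lipophilic compound, a lower number a more polar compound), compound 2 holds the second highest of the three values. Its nearest neighbour is compound 3: a number 0.05 log units lower from compound 2 to compound 3 (within the scatter). Its furthest is compound 1: a number 1.32 log units lower from compound 1 to compound 2 (beyond the scatter).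

Compound 4 `O=C1O[C@@H](Cn2ccnn2)CN1c1ccc(-n2cc(-c3ccccn3)cn2)c(F)c1` differs from compound 2 in one place: 1H-1,2,3-triazol-1-yl in place of 4-((methoxycarbonyl)methyl)piperidin-1-yl on a saturated chain carbon bound to a saturated ring carbon. The step that bears most directly on this is the one where a 1H-imidazol-1-yl replaced the same group: a number 0.05 log units lower from compound 2 to compound 3 (within the scatter), a change within the scatter. The step from compound 1 to compound 3, a number 1.37 log units lower from compound 1 to compound 3 (beyond the scatter), shows how far such small aromatic rings sit from the piperidin-1-yl of compound 1, but does not start from compound 2. With a five-membered aromatic ring again entering, I expect no step beyond the scatter: a number 0.18 log units lower from compound 2 to compound 4 (within the scatter). Compound 4 is therefore estimated at 1.6, between 1.1 and 2.1.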

Compound 4, partition coefficient: 2
For compound 4 the middle estimate is 0.40 log units below the measured one, and the stated range covers the measured number.
By their numbers in this assay, from the lowest: compounds 3, 2 and 4 (each within the scatter of the next); then compound 1.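

In this assay, the 1H-1,2,3-triazol-1-yl group on this saturated chain carbon cannot be told apart from the 4-((methoxycarbonyl)methyl)piperidin-1-yl group (a number 0.22 log units higher from compound 2 to compound 4 (within the scatter)) or from the 1H-imidazol-1-yl group (a number 0.27 log units higher from compound 3 to compound 4 (within the scatter)). So a second five-membered aromatic ring joins the same cluster of values, and only the plain piperidin-1-yl of compound 1 stands clear of it (a number 1.10 log units lower from compound 1 to compound 4 (beyond the scatter)). No measurement shown here accounts for this grouping.

Still open, going by these compounds, is where a tetrazole ring, a morpholine or a piperidine carrying a free carboxylic acid would fall. On these data alone, it is also open whether the cluster would hold on a longer chain.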